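A few compounds are considered here, and "the series" means these few. Any claim that something is new, unique, unknown or untested is made for them only; others in the source may bear on it.

Compound 2, `NC(=O)C1CCN(Cc2ccc([C@H]3CC[C@]4(CC3)OOC3(O4)C4CC5CC(C4)CC3C5)cc2)CC1`, is the point of departure. In an ADME assay on microsomes from liver (Homo sapiens) for metabolic stability, read by LC-MS, tested at 1 uM (a lower number here means slower removal, a higher number faster removal of the compound), compound 2 gives 10 mL.min-1.g-1. Compound 3, `OC1(COc2ccc([C@H]3CC[C@]4(CC3)OOC3(O4)C4CC5CC(C4)CC3C5)cc2)CCNCC1`, gives 16 mL.min-1.g-1 in this assay, and the step of a 1.6-fold higher number from compound 2 to compound 3 (0.20 log units; within the scatter) is within the scatter, so the two cannot be ordered. Compound 1, `NCCOCCOc1ccc([C@H]2CC[C@]3(CC2)OOC2(O3)C3CC4CC(C3)CC2C4)cc1`, gives only a limit in this assay, < 7 mL.min-1.g-1, as noted in the limit of < 7 mL.min-1.g-1 in this assay, at which 1 of the 3 values shown sits.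

Compound 4, `NCCCCOc1ccc([C@H]2CC[C@]3(CC2)OOC2(O3)C3CC4CC(C3)CC2C4)cc1`, differs from compound 2 in one place: 4-aminobutoxy in place of (4-carbamoylpiperidin-1-yl)methyl on an aromatic carbon. The measured steps that bear on this change are an at least 1.4-fold higher number from compound 1 to compound 2 (0.15 log units; that floor lies within the scatter), whose floor lies within the scatter, and an at least 2.2-fold higher number from compound 1 to compound 3 (0.35 log units; beyond the scatter), which is beyond it; both move away from the compound with the open aminoalkoxy chain. Since compound 4 carries a 4-aminobutoxy chain, its number is expected to sit near the limit shown by compound 1 or modestly below compound 2, with a 1.4-fold lower number from compound 2 to compound 4 (0.15 log units; within the scatter) as the expected step. For compound 4 the estimate is therefore 7 mL.min-1.g-1, between 3.5 mL.min-1.g-1 and 14 mL.min-1.g-1, with a fair chance that only a limit is reported.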

Compound 4, intrinsic clearance in microsomes: < 7 mL.min-1.g-1
Compound 4 ended at the assay's limit (the forecaster's own chance of this, stated with the estimate: 45%); the middle value lies on the limit itself.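

With 4-aminobutoxy in place of (4-carbamoylpiperidin-1-yl)methyl on the aromatic carbon, the result is an at least 1.4-fold lower number from compound 2 to compound 4 (0.15 log units; that floor lies within the scatter), so this change alone does not separate the two compounds. The other readable step, an at least 2.2-fold lower number from compound 3 to compound 4 (0.35 log units; beyond the scatter), places a second open aminoalkoxy chain clearly apart from the 4-hydroxypiperidin-4-yl compound in this assay, although the step to compound 2 does not support the same separation. The step between compound 1 and compound 4 cannot be read, and the ringless chains now both sit at the end of the measurable range: the limit of < 7 mL.min-1.g-1 in this assay, at which 2 of the 4 values shown sit.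

As far as these compounds go, whether the length of the chain matters at this position stays open. Also open, from the compounds shown here alone, is whether a tertiary amine or a carboxylic acid at the end of the 4-aminobutoxy chain would stay at that limit.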